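A few compounds are considered here, and "the series" means these few. Any claim that something is new, unique, unknown or untested is made for them only; others in the source may bear on it.

Of the compounds shown here, three have so far been measured in a functional assay on PC-12 cells (Rattus norvegicus) for cytotoxicity, read by MTT assay, with a stated time of 24 h, tested at 1 uM; on this read-out higher numbers stand for a stronger effect at the one concentration tested and lower numbers for a weaker effect. Compound 1 `COc1ccc(C(c2ccc(OC)cc2)N2CCN(C(=O)COc3ccccc3C)CC2)cc1` gives 3.75%, compound 2 `COc1ccc(OCC(=O)N2CCN(C(c3ccc(F)cc3)c3ccc(F)cc3)CC2)cc1` gives 5.26%, and compound 3 `COc1ccc(OCC(=O)N2CCN(C(c3ccc(Br)cc3)c3ccc(Br)cc3)CC2)cc1` gives 7.06%. Compound 2 sits between the other two on these numbers, but both gaps lie within the scatter of repeated measurements, so the three cannot be separated on these readings. Compound 4 `COc1ccccc1OCC(=O)N1CCN(C(c2ccc(F)cc2)c2ccc(F)cc2)CC1` is built from the same atoms as compound 2, joined differently: 2-methoxyphenyl in place of 4-methoxyphenyl on an oxygen on a saturated carbon. Among the compounds with values here, no measured pair shows what such a rearrangement does in this assay, so the step that this estimate means a number 0.3 percentage points lower from compound 2 to compound 4 (within the scatter) is expected to be none beyond the scatter. Accordingly compound 4 is estimated to give 5%, in a range from 0% to 12%.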

Compound 4, a percentage reported as activity, at one concentration (the size of the read-out at that concentration, not a potency): 45.9%
Compound 4: the middle estimate sits 40.9 percentage points below what was measured, outside the stated range (above it).
By their numbers in this assay, from the lowest: compounds 1, 2 and 3 (each within the scatter of the next); then compound 4.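

In this assay, within the data shown here, moving the methoxy group alone, with no atom gained or lost, matters greatly: 2-methoxyphenyl in place of 4-methoxyphenyl gives a number 40.6 percentage points higher from compound 2 to compound 4 (beyond the scatter) and is the first change here to reach beyond the scatter. Among these compounds, this place, on an oxygen on a saturated carbon, therefore responds to how the same atoms are arranged, which the earlier compounds could not show. Nothing available explains why. Open, on these data alone, is whether 3-methoxyphenyl here would read closer to compound 2 or compound 4, and whether 2-ethoxyphenyl or 2-chlorophenyl would match 2-methoxyphenyl. As far as these compounds go, whether the same rearrangement has this effect on the core of compound 3 also remains open.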